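Bromophenyl ethers on the shared core: moving the bromine

The source may report more compounds than this note shows. Statements on the series, on what has been measured and on what is new or still open speak of the compounds shown alone.

Measured so far in a functional assay on MDA-MB-231 cells (Homo sapiens) for antiproliferative activity, read by MTT assay, with a stated time of 72 h; on this read-out lower numbers stand for stronger inhibition and higher numbers for weaker inhibition:
compound 1 `NC1=NC2(CCSCC2)N(OCCCOc2cccc(Cl)c2Cl)C(N)=N1` — 1 nM
compound 2 `NC1=NC2(CCSCC2)N(OCCCOc2ccc(Br)cc2)C(N)=N1` — 440 nM
compound 3 `CC(C)(C)c1ccc(OCCCON2C(N)=NC(N)=NC23CCSCC3)cc1` — 1 nM

Compound 2 stands at the highest of the three numbers in this assay; compound 1 and compound 3 both sit far below it. Within the data shown here, two steps touch the aryl ether end of the shared core and both are large: a 440-fold higher number from compound 1 to compound 2 (2.64 log units; beyond the scatter) and a 440-fold lower number from compound 2 to compound 3 (2.64 log units; beyond the scatter). Each shows that the aryl ring is a place where a single change moves the number a long way. Neither step repeats the change to compound 4 `NC1=NC2(CCSCC2)N(OCCCOc2cccc(Br)c2)C(N)=N1`, which is 3-bromophenyl in place of 4-bromophenyl on an oxygen on a saturated carbon. Among the measured compounds shown here, the only guidance is indirect: compound 2, with 4-bromophenyl, gives 440 nM, whereas compound 1, with 2,3-dichlorophenyl, gives 1 nM, so a halogen in another arrangement on the ring is compatible with a low number. Compound 4 is therefore expected to give a lower number than compound 2, of uncertain size, with the step estimated as a 7.3-fold lower number from compound 2 to compound 4 (0.87 log units; beyond the scatter). Compound 4 is estimated at 60 nM, within the range 8 nM to 450 nM.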

Compound 4, half-maximal inhibitory concentration: 60 nM
Compound 4: middle estimate and measured number agree at the digits printed, within the range that was stated.
By their numbers in this assay, from the lowest: compounds 1 and 3 (each within the scatter of the next); then compound 4; then compound 2.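

In this assay, among these compounds, moving the bromine alone, with the same atoms on the ring, gives a 7.3-fold lower number from compound 2 to compound 4 (0.87 log units; beyond the scatter) and so separates the place of the halogen from its kind and number, which the earlier steps changed together. The move closes only part of the gap, since 3-bromophenyl in place of 2,3-dichlorophenyl still gives a 60-fold higher number from compound 1 to compound 4 (1.78 log units; beyond the scatter) and a single bromine in the new place does not reach the number of compound 1. Nothing at hand accounts for either step.

Open, as far as these compounds go, is whether the same move has a step of similar size with chloro or methoxy in place of bromo, and whether the tert-butyl group of compound 3 responds to it at all. A longer chain on the oxygen could also alter how much the arrangement on the aryl ring matters.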